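This account rests on a few compounds, and the source may have more. Where it says the series, first, only, none or still open, it means among the compounds named here.

Measured so far:
compound 1, `CCCCSC1=N[C@@H](C(=O)OC)[C@@H]2C(=O)N(c3ccccc3)C(=O)[C@H]12`: 82%
compound 2, `COC(=O)[C@H]1N=C(SCc2ccccc2)[C@H]2C(=O)N(c3ccccc3)C(=O)[C@H]21`: 76%

Two compounds on the shared core have been run in a functional assay for inhibition, tested at 100 uM; on this read-out lower numbers stand for less inhibition and higher numbers for more inhibition at the one concentration tested (going by the name of the read-out). Compound 1 gives 82%, the higher of the two numbers. Compound 2 gives 76%, which lies within the usual scatter of the number for compound 1, so the two cannot be ranked on this read-out. Going by the values given here, no pair of measured compounds differs in only one place, so no step has yet been measured in this assay.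

Compound 3, `CCCSC1=N[C@@H](C(=O)OC)[C@@H]2C(=O)N(c3ccccc3)C(=O)[C@H]12`, is not yet measured. It differs from compound 1 as follows: hydrogen in place of methyl on a saturated chain carbon, three bonds along the chain from a sulfur. The same difference, cut one bond further out, reads butyl to propyl. Among the compounds with values here, nothing measured so far shows what hydrogen in place of methyl on this chain does in this assay; the only comparison available, compound 1 against compound 2, stays inside the scatter. The step of a number 4 percentage points lower from compound 1 to compound 3 (within the scatter) is therefore expected to be small, in either direction, and not beyond the scatter. Compound 3 is estimated at 78%, with a range from 62% to 90%.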

Compound 3, a percentage reported as inhibition, at one concentration (the size of the read-out at that concentration, not a potency): 86%
Compound 3: middle estimate off by 8 percentage points, on the low side, and the stated range covers the measured number.
By their numbers in this assay, from the lowest: compounds 2, 1 and 3 (each within the scatter of the next).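

Hydrogen in place of methyl on a saturated chain carbon, three bonds along the chain from a sulfur, reads in this assay as a number 4 percentage points higher from compound 1 to compound 3 (within the scatter), the first step in the series that can be read at a single place. Going by these compounds alone, on this read-out, butyl to propyl therefore gives no change that can be told from the scatter, and compound 1 and compound 3 cannot be ranked; the result concerns only this pair and this one concentration. No measurement at hand bears on why the two chains read alike.

Open, going by these compounds, is whether this chain position stays as flat for groups further from butyl and propyl, such as an ethyl, a longer chain like hexyl, or a chain ending in an amine or a carboxylic acid. Also open, on these data alone, is whether butyl and propyl would still read alike as potencies, since a percentage at one concentration does not give a potency.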